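Trading methylsulfanyl for trifluoromethyl on the shared core

The source may report more compounds than this note shows. Statements on the series, on what has been measured and on what is new or still open speak of the compounds shown alone.

Measured in a functional assay on MDA-MB-231 cells (Homo sapiens) for antiproliferative activity, read by MTT assay, with a stated time of 72 h; on this read-out higher numbers stand for weaker inhibition and lower numbers for stronger inhibition:
compound 1 `O=C(CCc1cccc2c1B(O)OC2)Nc1cccc(-c2ccccc2)c1`: 220 nM
compound 2 `CSc1cccc(-c2cccc(NC(=O)CCc3cccc4c3B(O)OC4)c2)c1`: 150 nM

Among the compounds with values here, only two numbers exist so far, and compound 2, at 150 nM, lies within the scatter of compound 1. Compound 3 `O=C(CCc1cccc2c1B(O)OC2)Nc1cccc(-c2cccc(C(F)(F)F)c2)c1` brings a new change, trifluoromethyl in place of methylsulfanyl on an aromatic carbon. Within the data shown here, only one measured step bears on this carbon, a 1.5-fold lower number from compound 1 to compound 2 (0.17 log units; within the scatter), where methylsulfanyl replaced hydrogen. With so small a precedent, no step beyond the scatter is expected in this assay, and no direction can be favoured. The estimated step is a 1.2-fold higher number from compound 2 to compound 3 (0.08 log units; within the scatter). For compound 3 the expected value is 180 nM, with an estimated range of 80 nM to 400 nM.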

Compound 3, half-maximal inhibitory concentration: 410 nM
Estimate against measurement, compound 3: 2.3-fold (0.36 log units) below; measured number outside the range, above it.
By their numbers in this assay, from the lowest: compounds 2, 1 and 3 (each within the scatter of the next, the first and the last beyond it).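

In this assay, within the data shown here, this aromatic carbon does distinguish between its groups: trading methylsulfanyl for trifluoromethyl gives a 2.7-fold higher number from compound 2 to compound 3 (0.44 log units; beyond the scatter) and is the first step here to pass the scatter. Set against hydrogen, trifluoromethyl gives a 1.9-fold higher number from compound 1 to compound 3 (0.27 log units; within the scatter) and stays within the scatter, so the two groups separate from each other while neither separates from hydrogen. Nothing available explains this difference.

On these data alone, whether an amine or a carboxylic acid on this carbon would sit closer to methylsulfanyl or to trifluoromethyl remains open. So does the outcome for a longer chain such as ethyl.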